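This account rests on a few compounds, and the source may have more. Where it says the series, first, only, none or still open, it means among the compounds named here.

In a functional assay on HCT-116 cells (Homo sapiens) for antiproliferative activity, read by CCK-8 assay, with a stated time of 72 h, tested at 2 uM (on this read-out higher numbers stand for a stronger effect at the one concentration tested and lower numbers for a weaker effect), compound 1 `Cc1ccc(Nc2nc(Cl)nc3c2ncn3Cc2ccc(C(=O)Nc3ccccc3N)cc2)cc1` gives 76.3%. Compound 2 `Cc1ccc(Nc2nc(Cl)nc3c2ncn3Cc2ccc(/C=C/C(=O)Nc3ccccc3N)cc2)cc1` differs from it in one place, and the step is large: a number 76 percentage points lower from compound 1 to compound 2 (beyond the scatter). Compound 2 thus gives 0.27%, the lowest of the three numbers seen; compound 3 `Nc1ccccc1NC(=O)c1ccc(COCNc2nc(Nc3ccc(-c4ccccc4)cc3)c3ncn(C4CCCC4)c3n2)cc1` gives 9.41%, which lies within the usual scatter of that number, while compound 1 stands well beyond it.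

Compound 4 `Nc1ccccc1NC(=O)/C=C/c1ccc(Cn2cnc3c(NCc4ccccc4)nc(Cl)nc32)cc1` has the same atoms as compound 2, joined differently: benzyl in place of 4-methylphenyl on a nitrogen on an aromatic ring. Among the compounds with values here, no measured step touches this part of the molecule; the one measured step, from compound 1 to compound 2, concerns a different part, so it offers no direct guide. The only fact in hand is that compound 2 sits near the floor of the read-out, so there is little room for a step downward, and any change would have to show as a rise. With nothing to argue for a large gain, compound 4 is expected to stay low, at about 10%, within 0% to 40%, an expected step of a number 9.7 percentage points higher from compound 2 to compound 4 (within the scatter).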

Compound 4, a percentage reported as inhibition, at one concentration (the size of the read-out at that concentration, not a potency): 2.85%
Compound 4: the middle estimate sits 7.2 percentage points above what was measured; the measured number falls inside the stated range.
By their numbers in this assay, from the lowest: compounds 2, 4 and 3 (each within the scatter of the next); then compound 1.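

Placing benzyl instead of 4-methylphenyl on the nitrogen gives, in this assay, a number 2.6 percentage points higher from compound 2 to compound 4 (within the scatter) and is the only step shown at this position. The two groups have the same heavy-atom count and the same six-membered aromatic ring, and with the ethenyl-containing arm kept in place, this swap gives no change that can be told from scatter. Nothing available explains this result.

From the compounds shown here alone, compound 2 and compound 4 both read close to the bottom of the scale, so it remains open whether benzyl and 4-methylphenyl would also read alike on the core of compound 1, which has no ethenyl group and a much higher value. Also open, going by these compounds, is what a 2-phenylethyl group or a morpholine at this position would give.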